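Amino in place of chloro on the shared core

A few compounds are considered here, and "the series" means these few. Any claim that something is new, unique, unknown or untested is made for them only; others in the source may bear on it.

Compound 1 `ClCc1ccccc1Cn1cnc2c(Cl)nc(Cl)nc21` carries chloro groups on its core and a chloromethyl-substituted benzyl group. In a functional assay on HT-29 cells (Homo sapiens) for cytotoxicity, read by sulforhodamine B assay, with a stated time of 48 h (on this read-out higher numbers stand for lower toxicity in this test and lower numbers for higher toxicity in this test), compound 1 gives only a limit of the assay, > 100000 nM. Compound 2 `ClCc1cccc(Cn2cnc3c(Cl)nc(Cl)nc32)c1` and compound 3 `ClCc1ccc(Cn2cnc3c(Cl)nc(Cl)nc32)cc1` carry the same chloromethyl group at other points of the benzyl ring. In this assay compound 2 also returns only a limit, > 100000 nM. Compound 3 likewise gives only a limit in this assay, > 100000 nM. Compound 1 therefore stands nowhere distinct on the numbers shown: all values sit at the limit of > 100000 nM in this assay, at which 3 of the 3 values shown sit, and no ordering among compounds 1, 2 and 3 can be read.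

Compound 4 `Nc1nc(Cl)c2ncn(Cc3ccccc3CCl)c2n1` differs from compound 1 by amino in place of chloro on an aromatic carbon. Among the compounds with values here, no measured step of this kind exists in the set. For compound 4 the expected step is a step that the limit leaves unreadable from compound 1 to compound 4, in neither direction beyond the scatter, since compound 1 sits at the limit of > 100000 nM in this assay, at which 3 of the 3 values shown sit. Compound 4 is thus estimated at about 150000 nM in this assay, between 30000 nM and 600000 nM, most probably again reported only as a limit.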

Compound 4, concentration lethal to 50% of the cells: > 100000 nM
Compound 4 gave a limit, no number (the forecaster's own chance of this, stated with the estimate: 75%); the middle value does not contradict the limit.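

No step can be read from compound 1 to compound 4, because both results are limits in this assay: the limit of > 100000 nM in this assay, at which 4 of the 4 values shown sit.

As far as these compounds go, whether amino in place of chloro on an aromatic carbon alters the read-out in this assay remains open, as does any ordering among compound 1, compound 2, compound 3 and compound 4.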